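A benzyl group replaces 3-chloropropyl on the sulfonyl

This account rests on a few compounds, and the source may have more. Where it says the series, first, only, none or still open, it means among the compounds named here.

In a functional assay on Huh-7 cells (Homo sapiens) for cytotoxicity, read by MTT assay, with a stated time of 72 h (on this read-out lower numbers stand for higher toxicity in this test and higher numbers for lower toxicity in this test), compound 1 (`CCS(=O)(=O)N1CCC2(CC1)OOC1(CCCC1)OO2`) gives > 100 ug/mL as a limit of the assay. Compound 2 (`O=S(=O)(CCCCl)N1CCC2(CC1)OOC1(CCCC1)OO2`) likewise gives > 100 ug/mL as a limit, so it has no number to stand on. For the measured compounds named here, both sit at the same limit (the limit of > 100 ug/mL in this assay, at which 2 of the 2 values shown sit) and the one measured step (a step that the two limits leave unreadable from compound 1 to compound 2) has no readable size. Compound 3 (`O=S(=O)(Cc1ccccc1)N1CCC2(CC1)OOC1(CCCC1)OO2`) carries phenyl in place of 2-chloroethyl on a saturated chain carbon bound to a sulfonyl sulfur. With no measured size to carry over, no step beyond the scatter is expected (a number no higher from compound 2 to compound 3 (the limit leaves the size open)). In this assay compound 3 is estimated at 100 ug/mL with an expected range of 45 ug/mL to 200 ug/mL. A limit rather than a number may be expected again for compound 3.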

Compound 3, half-maximal cytotoxic concentration: > 100 ug/mL
Compound 3: no number, only a limit; the forecaster's own chance of this, stated with the estimate: 70%; the middle value lies on the limit itself.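

Compound 3 in this assay gives > 100 ug/mL, a limit and not a number. No step among compound 1, compound 2 and compound 3 can be read: the limit of > 100 ug/mL in this assay, at which 3 of the 3 values shown sit.

The compounds shown leave open whether their sulfonyl groups differ at all in this assay.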